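Demethylation of an aryl methyl ether in a cytotoxicity series

The source may hold more compounds than are shown below. What is called first, only, known or untested is meant among the compounds shown, and "the series" means these compounds.

Measured so far:
compound 1 `COc1ccc([C@H]2Oc3cc(OC)c(OC)cc3[C@@H]2C)cc1O`: > 19.4 ug/mL
compound 2 `COc1ccc(-c2oc3cc(OC)c(O)cc3c2C)cc1O`: "not active" (no number reported)

In a functional assay on A549 cells (Homo sapiens) for cytotoxicity, read by MTT assay (on this read-out higher numbers stand for weaker inhibition and lower numbers for stronger inhibition), compound 1 gives only a limit, > 19.4 ug/mL, which is where it stands on the numbers shown. Compound 2 is recorded in this assay as "not active" (no number reported), without a number. Among the measured compounds shown here, with no single number for either measured compound, no step between them can be sized; all that can be said is that neither shows measurable inhibition in this assay, and that compound 1 sits at the limit of > 19.4 ug/mL in this assay, at which 1 of the 2 values shown sits.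

Compound 3 `COc1ccc([C@H]2Oc3cc(OC)c(O)cc3[C@@H]2C)cc1O` is the untested member. It differs from compound 1 by hydrogen in place of methyl on an oxygen on an aromatic ring. For the measured compounds named here, no measured step of this kind is available in this assay, so the size of the change cannot be taken from the data; the expectation is a step of no size beyond the scatter, in no particular direction, given that compound 1 itself gives only a limit.

Compound 3 is therefore expected near 25 ug/mL in this assay, in a range from 10 ug/mL to 80 ug/mL. The expected step from the parent is a step that the limit leaves unreadable from compound 1 to compound 3, and a result reported only as a limit is the likeliest outcome.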

Compound 3, half-maximal inhibitory concentration: 7.7 ug/mL
Beside the measured number, compound 3's estimate is 3.2-fold (0.51 log units) above it, and the stated range ends above it.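

In this assay, hydrogen in place of methyl on an oxygen on an aromatic ring gives the first single number in the series shown, with compound 3 at 7.7 ug/mL. The methoxy to hydroxy change at this place on the shared core produces an at least 2.5-fold lower number from compound 1 to compound 3 (0.40 log units; beyond the scatter), which shows that this oxygen substituent matters for the read-out, something neither earlier entry could show on its own. The true size of the step remains unknown, and the printed figure is only a minimum because one end of the step is a limit: the limit of > 19.4 ug/mL in this assay, at which 1 of the 3 values shown sits.

Among the compounds shown here, compound 2 carries no number, and steps involving it cannot be read, leaving this single pair as the only evidence on the change, with no information on whether the same replacement would act similarly at another methoxy group on the core. Also open, as far as these compounds go, is whether the lower number depends on the hydroxy group specifically, a question that an amine at the same place or a longer chain such as ethyl on the same oxygen would address.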